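The source may report more compounds than this note shows. Statements on the series, on what has been measured and on what is new or still open speak of the compounds shown alone.

Three compounds share one core and differ only in the group on an amine nitrogen in a ring: compound 1 `O=C(/C=C/c1ccc(O)c(O)c1)N1CCN(c2ccccc2Cl)CC1`, compound 2 `COc1cccc(N2CCN(C(=O)/C=C/c3ccc(O)c(O)c3)CC2)c1` and compound 3 `O=C(/C=C/c1ccc(O)c(O)c1)N1CCN(c2ccc([N+](=O)[O-])cc2)CC1`. In a functional assay on A549 cells (Homo sapiens) for antiproliferative activity, read by MTT assay, with a stated time of 48 h (on this read-out lower numbers stand for stronger inhibition and higher numbers for weaker inhibition), compound 1 gives 1.44 ug/mL, compound 2 gives 1.27 ug/mL and compound 3 gives 1.56 ug/mL. Compound 3 therefore sits within the usual scatter of both other compounds.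

Compound 4 `Cc1ccc(N2CCN(C(=O)/C=C/c3ccc(O)c(O)c3)CC2)c(C)c1` differs from compound 3 at that same place: 2,4-dimethylphenyl in place of 4-nitrophenyl on an amine nitrogen in a ring, with 2,4-dimethylphenyl in place of 4-nitrophenyl on an amine nitrogen in a ring. Three measured swaps at this position bear on the change: a 1.1-fold lower number from compound 1 to compound 2 (0.05 log units; within the scatter), a 1.1-fold higher number from compound 1 to compound 3 (0.03 log units; within the scatter) and a 1.2-fold higher number from compound 2 to compound 3 (0.09 log units; within the scatter). All three stay within the scatter. Within the data shown here, no measured compound carries 2,4-dimethylphenyl, so this group remains untested, but no step beyond the scatter is expected in this assay, in either direction. The expected change is a 1.1-fold lower number from compound 3 to compound 4 (0.05 log units; within the scatter). Compound 4 is estimated at 1.4 ug/mL, with an expected range from 0.8 ug/mL to 2.4 ug/mL.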

Compound 4, half-maximal inhibitory concentration: 1.02 ug/mL
Beside the measured number, compound 4's estimate is 1.4-fold (0.14 log units) above it; measured number inside the range.
By their numbers in this assay, from the lowest: compounds 4, 2, 1 and 3 (each within the scatter of the next).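

Replacing 4-nitrophenyl with 2,4-dimethylphenyl on an amine nitrogen in a ring removes all the oxygen and nitrogen of that group, leaving only carbon, along with the 2 hydrogen-bond acceptors counted for 4-nitrophenyl. Even so, this assay shows a 1.5-fold lower number from compound 3 to compound 4 (0.18 log units; within the scatter) for this swap. The other two comparisons agree, with a 1.2-fold lower number from compound 2 to compound 4 (0.10 log units; within the scatter) and also a 1.4-fold lower number from compound 1 to compound 4 (0.15 log units; within the scatter) as the remaining steps, so all four aryl groups now give numbers that cannot be told apart at this position. Nothing measured here explains this tolerance.

From the compounds shown here alone, what remains open is whether the position stays this forgiving once the aromatic ring is replaced, for example by cyclohexyl. A phenyl ring carrying a carboxylic acid or an amine is equally untested in the compounds shown.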